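Nitro in place of methyl on the aryl imine

A few compounds are considered here, and "the series" means these few. Any claim that something is new, unique, unknown or untested is made for them only; others in the source may bear on it.

Compound 2 `Cc1ccc(/C=N/c2nnc(SCc3c[se]c(-c4ccccc4)n3)s2)cc1` is one of two measured members of a shared core that carries an arylmethylidene imine. Among the compounds with values here, in a functional assay on L1210 cells (Mus musculus) for antiproliferative activity, read by CCK-8 assay (a higher number here means a weaker inhibitor, a lower number a stronger inhibitor), compound 2 gives 58600 nM, the highest of the two numbers so far. Its nearest neighbour, compound 1 `Oc1ccccc1/C=N/c1nnc(SCc2c[se]c(-c3ccccc3)n2)s1`, gives 38700 nM in this assay, and the step of a 1.5-fold higher number from compound 1 to compound 2 (0.18 log units; within the scatter) is within the scatter, so the two cannot be ordered.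

Compound 3 `O=[N+]([O-])c1ccc(/C=N/c2nnc(SCc3c[se]c(-c4ccccc4)n3)s2)cc1` differs from compound 2 by nitro in place of methyl on an aromatic carbon. Within the data shown here, the only step measured so far exchanges a substituted phenyl on the carbon with a double bond to nitrogen and moved the number by little, and no measured pair touches a nitro group, so the data give no ground for a step beyond the scatter here. The estimate for compound 3 in this assay therefore rests on compound 2 alone, at 58600 nM, and the step of a 1.2-fold lower number from compound 2 to compound 3 (0.07 log units; within the scatter) is expected to stay within the scatter. Compound 3 is estimated at 50000 nM, with a range from 15000 nM to 150000 nM.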

Compound 3, half-maximal inhibitory concentration: > 100000 nM
Compound 3 ended at the assay's limit; the forecaster's own chance of this, stated with the estimate: 15%; middle value at least 2.0-fold (0.30 log units) away from the limit.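

The reading for compound 3 is a limit of the assay and not a number: the limit of > 100000 nM in this assay, at which 1 of the 3 values shown sits. At the aromatic carbon para to a large group, nitro in place of methyl gives an at least 1.7-fold higher number from compound 2 to compound 3 (0.23 log units; that floor lies within the scatter), so the floor of this step cannot separate the two compounds, although the true distance may be larger and the limit hides it. Within the data shown here, the broader exchange on the carbon with a double bond to nitrogen, 4-nitrophenyl in place of 2-hydroxyphenyl, gives an at least 2.5-fold higher number from compound 1 to compound 3 (0.41 log units; beyond the scatter), and this is the first step at this position to pass beyond the scatter, whereas the exchange of 2-hydroxyphenyl for 4-methylphenyl did not.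

On these data alone, with three aryl groups in view, it stays open whether the nitro group itself or the move from 2-hydroxyphenyl to a group para to a large group accounts for that step, since compound 2 cannot be ordered against either neighbour. As far as these compounds go, how an amine or a carboxylic acid on the same aromatic carbon would read in this assay also remains open, as does whether any group here can bring the number down from the level of compound 1.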